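Compound 3 Expected Between Two Measured Neighbours

A few compounds are considered here, and "the series" means these few. Any claim that something is new, unique, unknown or untested is made for them only; others in the source may bear on it.

Two measured compounds share one core and differ only in the group on the carbonyl carbon. Compound 1 `COc1cc(Cl)cc(-c2nn(-c3cccc(NC(=O)c4ccc(Cl)c(Cl)c4)c3)cc2-c2ccncc2)c1` carries a 3,4-dichlorophenyl there, and compound 2 `COc1cc(Cl)cc(-c2nn(-c3cccc(NC(=O)Nc4cccc(C(F)(F)F)c4)c3)cc2-c2ccncc2)c1` carries a (3-(trifluoromethyl)phenyl)amino. In a functional assay on HCT-15 cells (Homo sapiens) for inhibition, read by sulforhodamine B assay, with a stated time of 48 h, tested at 10 uM (on this read-out higher numbers stand for a weaker effect at the one concentration tested and lower numbers for a stronger effect), compound 1 gives 57.9%, whereas compound 2 gives 7.83%, the lowest of the two numbers and hence the stronger effect at the tested concentration; the move from one to the other is a number 50.1 percentage points lower from compound 1 to compound 2 (beyond the scatter).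

Compound 3 `COc1cc(Cl)cc(-c2nn(-c3cccc(NC(=O)c4cccc(C(F)(F)F)c4)c3)cc2-c2ccncc2)c1` is not yet measured. It differs from compound 2 as follows:
3-(trifluoromethyl)phenyl in place of (3-(trifluoromethyl)phenyl)amino on a carbonyl carbon

Going by the values given here, the only measured step that bears on this change is the one from compound 1 to compound 2, and that step altered the aryl group and the amino link together, so the two contributions cannot be separated from the data. Compound 3 keeps the aryl of compound 2 while returning to the direct carbonyl attachment seen in compound 1, and the step from compound 2 to compound 3 is therefore expected to be a number 27.2 percentage points higher from compound 2 to compound 3 (beyond the scatter), upward and beyond the scatter, yet smaller than the full gap between the two measured compounds. Compound 3 is accordingly estimated at 35%, within a range from 10% to 65%.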

Compound 3, a percentage reported as activity, at one concentration (the size of the read-out at that concentration, not a potency): 33.2%
For compound 3 the middle estimate is 1.8 percentage points above the measured one, within the range that was stated.
By their numbers in this assay, from the lowest: compound 2; then compound 3; then compound 1.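

Read together, the new steps split the earlier combined change on the carbonyl carbon into two separate parts, each beyond the scatter. In this assay, with the 3-(trifluoromethyl)phenyl group held fixed, removing the amino link gives a number 25.4 percentage points higher from compound 2 to compound 3 (beyond the scatter) and thus a weaker effect, while with the direct carbonyl attachment held fixed, exchanging the aryl group gives a number 24.7 percentage points lower from compound 1 to compound 3 (beyond the scatter) and thus a stronger effect. Both the link and the aryl group therefore matter at this position, and neither change alone accounts for the whole of a number 50.1 percentage points lower from compound 1 to compound 2 (beyond the scatter) in this set, though no measurement here explains how either one acts.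

The compounds shown leave open whether (3,4-dichlorophenyl)amino on the same carbonyl carbon would complete the pattern, with the amino link again giving the stronger effect on that aryl group, or whether the link's contribution depends on the 3-(trifluoromethyl)phenyl group. They also leave open how a methylene or an oxygen link in place of the amino link would read, and whether any of these steps carries over to cell lines other than the one tested here.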